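Capping the amine of a threonine-derived tetradecylamide

A few compounds are considered here, and "the series" means these few. Any claim that something is new, unique, unknown or untested is made for them only; others in the source may bear on it.

Compound 1, `CCCCCCCCCCCCCCNC(=O)[C@@H](N)[C@@H](C)O`, is a small amide built from an amino acid and a long saturated chain. In a functional assay on MCF7 cells (Homo sapiens) for cytotoxicity, read by MTT assay, with a stated time of 48 h (on this read-out higher numbers stand for weaker inhibition and lower numbers for stronger inhibition), compound 1 gives 10700 nM, the lower of the two numbers measured here. Compound 2, `CCCCCCCCCCCCCCCCCCNC(=O)[C@@H](N)[C@@H](C)O`, carries a longer chain; in this assay compound 2 gives 27400 nM. Going by the values given here, the one measured step is a 2.6-fold higher number from compound 1 to compound 2 (0.41 log units; beyond the scatter), a change at the far end of the chain.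

Compound 3, `CCCCCCCCCCCCCCNC(=O)[C@@H](NC(=O)c1ccco1)[C@@H](C)O`, keeps the chain of compound 1 and instead changes the amine: (furan-2-yl)carbonyl in place of hydrogen on an amine nitrogen. Among the compounds with values here, no measured step touches that part of the molecule, so the chain-extension step gives no direct guide, and the expectation rests only on the fact that the rest of compound 1 is unchanged. The middle estimate for compound 3 is therefore set close to the number of compound 1, with a wide range in both directions, and this amounts to an expected step of a 1.1-fold higher number from compound 1 to compound 3 (0.05 log units; within the scatter). On that basis compound 3 is expected to give about 12000 nM, plausibly anywhere from 3000 nM to 45000 nM.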

Compound 3, half-maximal inhibitory concentration: 105000 nM
The estimate for compound 3 lay 8.8-fold (0.94 log units) below the measured number; the whole stated range lies below it.
By their numbers in this assay, from the lowest: compound 1; then compound 2; then compound 3.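

In this assay the amine nitrogen of compound 1 proves to be a place where a change registers: (furan-2-yl)carbonyl in place of hydrogen on this nitrogen gives a 9.8-fold higher number from compound 1 to compound 3 (0.99 log units; beyond the scatter) and so moves the number towards weaker inhibition. The earlier step (a 2.6-fold higher number from compound 1 to compound 2 (0.41 log units; beyond the scatter)) changed only the far end of the chain and said nothing about this end of the molecule, whereas this new step is the larger of the two and shows that replacing the amine hydrogen alone is enough to shift the number well beyond the scatter. Nothing measured here accounts for the weaker number, so the step stands as an observation without a known cause.

With a single group shown on this nitrogen, it remains open whether the shift belongs to the five-membered aromatic ring or to the carbonyl that carries it, a question that a simple acetyl or a benzoyl on the same nitrogen would help to settle. As far as these compounds go, it is also open whether (furan-2-yl)carbonyl would produce a similar step on the longer chain of compound 2.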